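A few compounds are considered here, and "the series" means these few. Any claim that something is new, unique, unknown or untested is made for them only; others in the source may bear on it.

In a functional assay on HUVEC cells (Homo sapiens) for cytotoxicity (on this read-out higher numbers stand for an effect only at larger amounts of compound and lower numbers for an effect already at smaller amounts), compound 1 `COC1=C(C)C(=O)/C(=C(O)/C=C/c2ccc(Br)cc2)C(=O)C1(C)C` gives 3.6 ug/mL, compound 2 `COC1=C(C)C(=O)/C(=C(O)/C=C/c2ccc(F)cc2)C(=O)C1(C)C` gives 2 ug/mL and compound 3 `C=Cc1ccccc1/C=C/C(O)=C1/C(=O)C(C)=C(OC)C(C)(C)C1=O` gives 1.1 ug/mL. Compound 3 therefore stands clearly apart only from compound 1, with a 3.3-fold lower number from compound 1 to compound 3 (0.51 log units; beyond the scatter), while a 1.8-fold lower number from compound 2 to compound 3 (0.26 log units; within the scatter) stays within the scatter. Compound 4 `COC1=C(C)C(=O)/C(=C(O)/C=C/c2ccco2)C(=O)C1(C)C` differs from compound 3 by furan-2-yl in place of 2-vinylphenyl on a double-bonded chain carbon bound to a double-bonded chain carbon. Those two steps changed the same place, and a 1.8-fold lower number from compound 1 to compound 2 (0.26 log units; within the scatter) shows the two halogenated compounds within the scatter. Going by the values given here, no furan-2-yl compound has a measured value, so only a small rise, not beyond the scatter, is expected, an estimated 1.9-fold higher number from compound 3 to compound 4 (0.28 log units; within the scatter). For compound 4 the estimated value is 2.1 ug/mL, with an expected range of 0.9 ug/mL to 5 ug/mL.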

Compound 4, concentration for half-maximal effect: 2.4 ug/mL
Estimate against measurement, compound 4: 1.1-fold (0.06 log units) below; the range from low to high includes it.
By their numbers in this assay, from the lowest: compounds 3, 2, 4 and 1 (each within the scatter of the next, the first and the last beyond it).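

In this assay, furan-2-yl at this place stands apart from 2-vinylphenyl, with a 2.2-fold higher number from compound 3 to compound 4 (0.34 log units; beyond the scatter), but not from the halogenated phenyl groups, with a 1.2-fold higher number from compound 2 to compound 4 (0.08 log units; within the scatter) and a 1.5-fold lower number from compound 1 to compound 4 (0.18 log units; within the scatter). The place therefore accepts a five-membered aromatic ring with a hetero atom without leaving the range of 4-fluorophenyl and 4-bromophenyl, and of these three groups only 2-vinylphenyl differs from furan-2-yl beyond the scatter. No available evidence gives a reason for this. From the compounds shown here alone, whether an amine or a carboxylic acid at this place would shift the number remains open.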